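The source may report more compounds than this note shows. Statements on the series, on what has been measured and on what is new or still open speak of the compounds shown alone.

Measured in a functional assay on KMS-11 cells (Homo sapiens) for antiproliferative activity, read by CellTiter-Glo, with a stated time of 72 h; a higher number here means a weaker inhibitor, a lower number a stronger inhibitor:
- compound 1 `COc1ccc(C(=O)N(Cc2ccncc2)Cc2cccc(OCCc3ccccc3)c2)cc1`: 16900 nM
- compound 2 `COc1ccc(C(=O)N(Cc2ccncc2)Cc2cccc(OCC(=O)c3ccc(Cl)cc3)c2)cc1`: 18500 nM

Within the data shown here, compound 2, at 18500 nM, stands level with compound 1, the only other compound measured. Compound 3 `COc1ccc(C(=O)N(Cc2ccncc2)Cc2cccc(OCc3cccc([N+](=O)[O-])c3)c2)cc1` changes one group of compound 2: 3-nitrophenyl in place of (4-chlorophenyl)carbonyl on a saturated chain carbon bound to an oxygen on an aromatic ring. In words, this puts 3-nitrophenyl in place of (4-chlorophenyl)carbonyl on a saturated chain carbon bound to an oxygen on an aromatic ring. Among the measured compounds shown here, one measured step bears on this, at the same place: a 1.1-fold higher number from compound 1 to compound 2 (0.04 log units; within the scatter). One step is thin evidence, but no change beyond the scatter is expected in this assay. The expected step is a 1.2-fold lower number from compound 2 to compound 3 (0.09 log units; within the scatter). Compound 3 is estimated at 15000 nM, with an expected range of 6000 nM to 32000 nM.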

Compound 3, half-maximal inhibitory concentration: 19600 nM
Compound 3: the middle estimate sits 1.3-fold (0.12 log units) below what was measured; the range from low to high includes it.
By their numbers in this assay, from the lowest: compounds 1, 2 and 3 (each within the scatter of the next).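

Putting 3-nitrophenyl in place of (4-chlorophenyl)carbonyl on this saturated chain carbon leaves the number in this assay within the scatter (a 1.1-fold higher number from compound 2 to compound 3 (0.03 log units; within the scatter)), and the same holds for 3-nitrophenyl in place of benzyl (a 1.2-fold higher number from compound 1 to compound 3 (0.06 log units; within the scatter)). Three different groups at this one place now give numbers that cannot be told apart, so this position has yet to show any effect on the read-out. Nothing available offers an explanation for this. Going by these compounds, whether an amine or a carboxylic acid here would separate from these three remains open. So does whether a longer chain at the same place would.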